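Swapping the carboxythiophene for a thiazole on the ring nitrogen

A few compounds are considered here, and "the series" means these few. Any claim that something is new, unique, unknown or untested is made for them only; others in the source may bear on it.

Measured so far:
- compound 1 `O=C(O)c1ccc(CN2CCC[C@H](OCc3cc(Cl)cc(Cl)c3)[C@@H]2c2ccccc2)s1`: 76000 nM
- compound 2 `OC[C@@H](O[C@H]1CCCN(Cc2ncc[nH]2)[C@H]1c1ccccc1)c1cc(Cl)cc(Cl)c1`: 7000 nM
- compound 3 `OC[C@@H](O[C@H]1CCCN(Cc2cccc3nonc23)[C@H]1c1ccccc1)c1cc(Cl)cc(Cl)c1`: 8000 nM

Of the compounds shown here, three share one core and have been tested in an assay on isolated protein for activation of cGMP-dependent protein kinase 1 (Homo sapiens), read by ADP-Glo, with stated times of 120 min and 40 min; on this read-out lower numbers stand for an effect already at smaller amounts and higher numbers for an effect only at larger amounts of compound. Compound 1 gives 76000 nM, the highest of the three numbers. Within the data shown here, compound 2 gives 7000 nM and compound 3 gives 8000 nM; both numbers lie well below that of compound 1, but both compounds differ from it in two places, so no single step links them to it.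

Compound 4 `Clc1cc(Cl)cc(CO[C@H]2CCCN(Cc3nccs3)[C@H]2c2ccccc2)c1` is not yet measured. It differs from compound 1 in one place: 1,3-thiazol-2-yl in place of 5-carboxythiophen-2-yl on a saturated chain carbon bound to an amine nitrogen in a ring. Among the measured compounds shown here, the only measured step at this position is a 1.1-fold higher number from compound 2 to compound 3 (0.06 log units; within the scatter), where one heteroaryl replaced another without moving the number beyond the scatter. Nothing measured speaks to the loss of the carboxylic acid itself. A modest move towards lower numbers is therefore expected, with wide uncertainty, and compound 4 is estimated at 30000 nM (range 7000 nM to 120000 nM), which would mean a 2.5-fold lower number from compound 1 to compound 4 (0.40 log units; beyond the scatter).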

Compound 4, half-maximal effective concentration: > 200000 nM
Compound 4 gave a limit, no number (the forecaster's own chance of this, stated with the estimate: 20%); middle value at least 6.6-fold (0.82 log units) away from the limit.
By their numbers in this assay, from the lowest: compounds 2 and 3 (each within the scatter of the next); then compound 1. At a limit, above all of these: compound 4.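

For compound 4, this assay gave only a limit, not a number: the limit of > 200000 nM in this assay, at which 1 of the 4 values shown sits.

Even so, the step can be read as an at least 2.6-fold higher number from compound 1 to compound 4 (0.42 log units; beyond the scatter), which shows that on this core, 1,3-thiazol-2-yl in place of 5-carboxythiophen-2-yl does shift the result beyond the scatter, towards higher numbers. Among these compounds, the only earlier step at this position, a 1.1-fold higher number from compound 2 to compound 3 (0.06 log units; within the scatter), joined two groups that both lack a carboxylic acid, so it could not show this.

This change removes the carboxy group and alters the ring at the same time, and the compounds shown do not tell these two parts apart. A plain thiophen-2-yl group, which lacks only the acid, or a 5-carboxy-1,3-thiazol-2-yl group, which keeps it on the new ring, would bear on that question.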